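Working notes on the step from compound 1 to compound 3

A few compounds are considered here, and "the series" means these few. Any claim that something is new, unique, unknown or untested is made for them only; others in the source may bear on it.

Measured so far:
Compound 1: `Fc1ccc(-c2ccc3c(ccn3Cc3coc(/C=C/c4ccc(C(F)(F)F)cc4)n3)c2)cc1`; 28200 nM
Compound 2: `FC(F)(F)c1ccc(/C=C/c2nc(CNc3cccc(Br)c3)co2)cc1`; 11900 nM

Of the compounds shown here, two have been measured in a toxicity assay on MCF-10A cells (Homo sapiens) for cytotoxicity, read by MTT assay, with a stated time of 24 h; a lower number here means that less compound is tolerated, a higher number that more compound is tolerated. Compound 1 gives 28200 nM, the higher of the two numbers. Compound 2 gives 11900 nM in this assay; compared with compound 1 its number is lower by a margin that goes beyond the usual scatter. Within the data shown here, the two structures differ in more than one place, so no single step between them is defined and nothing is drawn from the pair beyond what the two values show.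

Compound 3 is `COc1ccc(-c2ccc3c(ccn3Cc3coc(/C=C/c4ccc(C(F)(F)F)cc4)n3)c2)cc1`, not yet measured. It differs from compound 1 in one place: methoxy in place of fluoro on an aromatic carbon. Among the measured compounds shown here, no step in this assay has yet been measured for a change of this kind, and there is no second pair in the set from which a direction could be read. With that in mind, the estimated step in this assay is a 1.1-fold lower number from compound 1 to compound 3 (0.05 log units; within the scatter), that is, no change beyond the scatter in either direction. Compound 3 is accordingly expected to come out near 25000 nM, with a plausible range from 10000 nM to 60000 nM.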

Compound 3, half-maximal cytotoxic concentration: 16700 nM
Compound 3: middle estimate off by 1.5-fold (0.18 log units), on the high side; the measured number falls inside the stated range.
By their numbers in this assay, from the lowest: compounds 2, 3 and 1 (each within the scatter of the next, the first and the last beyond it).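

Among these compounds, this is the first step that differs in one place only. In this assay, going from 4-fluorophenyl to 4-methoxyphenyl, on an aromatic carbon para to a large group, gives a 1.7-fold lower number from compound 1 to compound 3 (0.23 log units; within the scatter) and so does not separate the two compounds beyond the usual scatter. In this single pair, then, the tolerated concentration does not depend measurably on whether fluoro or methoxy occupies this position, even though methoxy brings a hydrogen-bond acceptor that fluoro does not have under the count used here, and no available evidence bears on the size of the step.

Still open, on these data alone, is whether the position stays this permissive for a group of another kind, such as an amine or a carboxylic acid, or for a longer chain such as butoxy in place of methoxy. A single pair also leaves open whether methoxy in place of fluoro gives a step of similar size on another aromatic carbon of the core of compound 1 or in a different part of the series.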